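A Methoxy Addition on a Sulfonamide Scaffold at the Assay Limit

This account rests on a few compounds, and the source may have more. Where it says the series, first, only, none or still open, it means among the compounds named here.

Compound 1 `O=C1COc2ccc(-c3cccc(NS(=O)(=O)c4ccc(F)cc4)c3)cc2N1c1ccccc1`: > 40000 nM
Compound 2 `COc1cccc(N2C(=O)COc3ccc(-c4cnc5ccccc5c4)cc32)c1`: 23600 nM

Of the compounds shown here, two have been measured in a functional assay on A-375 cells (Homo sapiens) for antiproliferative activity, read by MTT assay, with a stated time of 72 h; on this read-out higher numbers stand for weaker inhibition and lower numbers for stronger inhibition. For compound 1 the result is only a limit of the assay, > 40000 nM, and it sits at the limit of > 40000 nM in this assay, at which 1 of the 2 values shown sits. Compound 2 gives 23600 nM in this assay. The unmeasured compound 3 `COc1ccc(N2C(=O)COc3ccc(-c4cccc(NS(=O)(=O)c5ccc(F)cc5)c4)cc32)cc1` differs from compound 1 in one place: methoxy in place of hydrogen on an aromatic carbon. For the measured compounds named here, no pair of measured compounds differs in one place, so no measured step sizes this change, and compound 1 and compound 2 differ in several places. The step that the limit leaves unreadable from compound 1 to compound 3 is expected to show nothing beyond the scatter. Compound 3 is therefore expected to give about 50000 nM, between 15000 nM and 150000 nM, most likely again as a limit.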

Compound 3, half-maximal inhibitory concentration: 38500 nM
For compound 3 the middle estimate is 1.3-fold (0.11 log units) above the measured one, and the stated range covers the measured number.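

In this assay the change from phenyl to 4-methoxyphenyl gives an at least 1.0-fold lower number from compound 1 to compound 3 (0.01 log units; that floor lies within the scatter) on this scaffold. For the compounds shown here, compound 3 gives 38500 nM as a measured number and not a limit, so the sulfonamide scaffold now has a first reading with methoxy at this place. Compound 1 is only a limit, so the true size of the step cannot be read: the limit of > 40000 nM in this assay, at which 1 of the 3 values shown sits.

From the compounds shown here alone, whether an amine, a hydroxyl or a chlorine at this place would move the number beyond the scatter stays open. So does the effect of methoxy elsewhere on this phenyl ring.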